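Chloro substitution on the pendant phenyl of compound 2

The compounds below may be only part of what the source reports. "The series", "measured", "known", "first", "only" and "open" are said of these compounds alone.

Measured compounds:
compound 1 `Nc1cccc(-c2cn3c(-c4ccc(Cl)cc4)csc3n2)c1` gives 22000 nM
compound 2 `C=C(Br)C(=O)Nc1cccc(-c2cn3c(-c4ccccc4)csc3n2)c1` gives 1300 nM

In a functional assay on L1210 cells (Mus musculus) for inhibition, read by cell counting, with a stated time of 2 days (a lower number here means a stronger inhibitor, a higher number a weaker inhibitor), compound 2 has the lowest number of the two measured; compound 1 stands beyond the scatter above it, and the two differ in more than one place, so no single step can be read from them. Compound 3 `C=C(Br)C(=O)Nc1cccc(-c2cn3c(-c4ccc(Cl)cc4)csc3n2)c1` carries the change chloro in place of hydrogen on an aromatic carbon of a six-membered aromatic ring of carbon only, para to a large group. Within the data shown here, no measured pair isolates this change, so the expected step from compound 2 to compound 3 is a 1.3-fold lower number from compound 2 to compound 3 (0.11 log units; within the scatter), none beyond the scatter. Compound 3 is estimated at 1000 nM, range 300 nM to 4000 nM.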

Compound 3, half-maximal inhibitory concentration: 1900 nM
The estimate for compound 3 lay 1.9-fold (0.28 log units) below the measured number, within the range that was stated.
By their numbers in this assay, from the lowest: compounds 2 and 3 (each within the scatter of the next); then compound 1.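

In this assay, phenyl to 4-chlorophenyl gives a 1.5-fold higher number from compound 2 to compound 3 (0.16 log units; within the scatter), so chloro in place of hydrogen at this position brings no step beyond the scatter. Among these compounds, with the 4-chlorophenyl held constant, (1-bromoethenyl)carbonyl in place of hydrogen on the nitrogen gives a 12-fold lower number from compound 1 to compound 3 (1.06 log units; beyond the scatter), the only single-place step here beyond the scatter. Nothing available accounts for either step. Still open, on these data alone, is how methoxy or trifluoromethyl would read at the chloro position. Also open, as far as these compounds go, is whether a plain acetyl on the nitrogen, lacking the bromoethenyl part, would give a similar step.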